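The compounds below may be only part of what the source reports. "The series", "measured", "known", "first", "only" and "open" are said of these compounds alone.

Measured so far in a functional assay on 1321-N1 cells for agonist activity at P2Y purinoceptor 6 (Homo sapiens), read by scintillation counting and inositol phosphate accumulation; a lower number here means that less compound is needed, a higher number that more compound is needed for the effect:
compound 1 `O=C(O)CCCO/N=c1/ccn([C@@H]2O[C@H](COP(=O)(O)OP(=O)(O)OP(=O)(O)O)[C@@H](O)[C@H]2O)c(=O)[nH]1` gives 697 nM
compound 2 `O=c1[nH]/c(=N\OCCCc2ccc(F)cc2)ccn1[C@@H]1O[C@H](COP(=O)(O)OP(=O)(O)OP(=O)(O)O)[C@@H](O)[C@H]1O` gives 1210 nM

Compound 2 stands highest of these two numbers, though its step from compound 1, a 1.7-fold higher number from compound 1 to compound 2 (0.24 log units; within the scatter), lies within the scatter. Compound 3 `O=c1[nH]/c(=N\OCCCc2cccc(I)c2)ccn1[C@@H]1O[C@H](COP(=O)(O)OP(=O)(O)OP(=O)(O)O)[C@@H](O)[C@H]1O` differs from compound 2 by 3-iodophenyl in place of 4-fluorophenyl on a saturated chain carbon, three bonds along the chain from an oxygen. Among the measured compounds shown here, only that one step touches the same place, and it exchanged a carboxy chain end for an aryl group without moving the number beyond the scatter; no measured step compares two aryl groups. No shift beyond the scatter in this assay is therefore expected. The expected step is a 1.0-fold lower number from compound 2 to compound 3 (0.00 log units; within the scatter). Compound 3 is estimated at 1200 nM, between 450 nM and 3200 nM.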

Compound 3, half-maximal effective concentration: 299 nM
The estimate for compound 3 lay 4.0-fold (0.60 log units) above the measured number, outside the stated range (below it).
By their numbers in this assay, from the lowest: compound 3; then compounds 1 and 2 (each within the scatter of the next).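

In this assay, among the compounds shown here, the choice of aryl group at this place does change the number: 3-iodophenyl in place of 4-fluorophenyl gives a 4.0-fold lower number from compound 2 to compound 3 (0.61 log units; beyond the scatter), the first step here beyond the scatter. 3-Iodophenyl in place of the carboxy chain end also gives a step beyond the scatter, a 2.3-fold lower number from compound 1 to compound 3 (0.37 log units; beyond the scatter), which 4-fluorophenyl did not. No measurement given accounts for this difference between the two aryl groups. Because the two groups differ in both halogen and ring placement, these compounds cannot separate the two, as 3-fluorophenyl or 4-iodophenyl could. Going by these compounds, how a longer chain would read also stays open.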